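The source may report more compounds than this note shows. Statements on the series, on what has been measured and on what is new or still open speak of the compounds shown alone.

Three analogues built on one shared core have been measured in a functional assay on BJAB cells (Homo sapiens) for antiproliferative activity, with a stated time of 4 days; on this read-out lower numbers stand for an effect already at smaller amounts and higher numbers for an effect only at larger amounts of compound. Compound 1 `COc1ccc(C)cc1-c1c(C)nn(-c2nc(-c3ccc(Cl)c(Cl)c3)c(SC(C)C)s2)c1C(=O)O` gives 9500 nM. Compound 2 `COc1cncc(-c2c(C)nn(-c3nc(-c4ccc(Cl)c(Cl)c4)c(SC(C)C)s3)c2C(=O)O)c1` gives 21000 nM. Among the compounds with values here, compound 3 `CCOc1ncccc1-c1c(C)nn(-c2nc(-c3ccc(Cl)c(Cl)c3)c(SC(C)C)s2)c1C(=O)O` gives 11000 nM, the second highest of the three numbers; its separation from compound 1 is a 1.2-fold higher number from compound 1 to compound 3 (0.06 log units; within the scatter) and from compound 2 is a 1.9-fold lower number from compound 2 to compound 3 (0.28 log units; within the scatter), so compound 3 sits with both inside the scatter, while the only step beyond the scatter among the measured compounds is a 2.2-fold higher number from compound 1 to compound 2 (0.34 log units; beyond the scatter). Compound 4 `Cc1cc(C#N)cc(-c2c(C)nn(-c3nc(-c4ccc(Cl)c(Cl)c4)c(SC(C)C)s3)c2C(=O)O)c1` differs from compound 3 by 3-cyano-5-methylphenyl in place of 2-ethoxypyridin-3-yl on an aromatic carbon. All three measured steps exchange the group on the same aromatic carbon and together span only a narrow band; none of them brings in a nitrile, so the expectation for this change rests on that narrow band alone. Compound 4 is therefore expected to show a 1.1-fold higher number from compound 3 to compound 4 (0.04 log units; within the scatter), with no step beyond the scatter. The estimate for compound 4 in this assay is 12000 nM, with a range from 5000 nM to 30000 nM.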

Compound 4, half-maximal effective concentration: 4800 nM
For compound 4 the middle estimate is 2.5-fold (0.40 log units) above the measured one; the measured number lies below the stated range.
By their numbers in this assay, from the lowest: compounds 4, 1, 3 and 2 (each within the scatter of the next, the first and the last beyond it).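

In this assay, the 3-cyano-5-methylphenyl group brings the first nitrile to this aromatic carbon, and the swap from a pyridine-bearing group now gives steps beyond the scatter, with a 2.3-fold lower number from compound 3 to compound 4 (0.36 log units; beyond the scatter) and a 4.4-fold lower number from compound 2 to compound 4 (0.64 log units; beyond the scatter). Against the carbon-only ring of compound 1, however, a 2.0-fold lower number from compound 1 to compound 4 (0.30 log units; within the scatter) stays inside the scatter, so compound 4 cannot be ranked ahead of compound 1 and the nitrile shows no separate gain over that group. Nothing available here accounts for these steps.

Compound 4 differs from compounds 2 and 3 in its ring, its nitrile and its methyl group all at once, so the share of each in the step remains unresolved. As far as these compounds go, it also remains open what a carboxamide or an aminomethyl group would give in place of the nitrile at this position.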